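Moving a trifluoromethyl across the benzoyl ring

The compounds below may be only part of what the source reports. "The series", "measured", "known", "first", "only" and "open" are said of these compounds alone.

Measured compounds:
compound 1 `O=C(c1ccccc1C(F)(F)F)N(/N=N/c1ccc([N+](=O)[O-])cc1Cl)c1ccc([N+](=O)[O-])cc1Cl`: 10600 nM
compound 2 `O=C(c1cccc(C(F)(F)F)c1)N(/N=N/c1ccc([N+](=O)[O-])cc1Cl)c1ccc([N+](=O)[O-])cc1Cl`: 1180 nM
compound 3 `O=C(c1ccccc1C(F)(F)F)N(/N=N/c1ccc([N+](=O)[O-])cc1C(F)(F)F)c1ccc([N+](=O)[O-])cc1C(F)(F)F`: 5350 nM

All three were tested in a functional assay on HeLa cells (Homo sapiens) for cytotoxicity, read by MTT assay, with a stated time of 72 h; on this read-out lower numbers stand for stronger inhibition and higher numbers for weaker inhibition. Compound 1 gives 10600 nM in this assay, and compound 2 gives 1180 nM. The two differ only at the carbonyl carbon, where the change 3-(trifluoromethyl)phenyl in place of 2-(trifluoromethyl)phenyl on a carbonyl carbon takes place, and the measured step there is a 9.0-fold lower number from compound 1 to compound 2 (0.95 log units; beyond the scatter). Compound 3 carries a different core; the difference between the core of compound 1 and the core of compound 3 is not broken down here. In this assay compound 3 gives 5350 nM, a number that sits within the scatter of compound 1 and is beyond the scatter above compound 2.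

Compound 4 `O=C(c1cccc(C(F)(F)F)c1)N(/N=N/c1ccc([N+](=O)[O-])cc1C(F)(F)F)c1ccc([N+](=O)[O-])cc1C(F)(F)F` is not yet measured. It stands to compound 3 as compound 2 stands to compound 1: the change 3-(trifluoromethyl)phenyl in place of 2-(trifluoromethyl)phenyl on a carbonyl carbon is the same change, made at the same place on a carbonyl carbon whose other neighbour is the amide-type nitrogen. Among the compounds with values here, the only guide to its size is the single earlier case, so the expectation rests on one pair alone. The step from compound 3 to compound 4 is expected to be of the same direction and roughly the same size, a 6.7-fold lower number from compound 3 to compound 4 (0.83 log units; beyond the scatter), because the earlier step was a 9.0-fold lower number from compound 1 to compound 2 (0.95 log units; beyond the scatter). On that basis compound 4 is estimated at 800 nM in this assay, with a plausible range from 250 nM to 2500 nM.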

Compound 4, half-maximal inhibitory concentration: 750 nM
For compound 4 the middle estimate is 1.1-fold (0.03 log units) above the measured one, and the stated range covers the measured number.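

In this assay, putting 3-(trifluoromethyl)phenyl in place of 2-(trifluoromethyl)phenyl on the carbonyl carbon gives a 7.1-fold lower number from compound 3 to compound 4 (0.85 log units; beyond the scatter) and so repeats on the core of compound 3 what was seen on the core of compound 1. Set side by side, the two steps run the same way and cannot be told apart in size: the same change on two cores in this assay, a 9.0-fold lower number (0.95 log units; beyond the scatter) from compound 1 to compound 2 and a 7.1-fold lower number (0.85 log units; beyond the scatter) from compound 3 to compound 4, 1.3-fold (0.10 log units) apart, within the scatter of two such steps. This shows that the change carried over in direction and in size between these two cores in this one cell assay, but it rests on two pairs only and does not show that the step would hold on any further core or in other cells, nor does it explain why the change has this effect.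

The compounds shown leave open whether the step belongs to the trifluoromethyl group itself or would also appear with a methoxy group, a nitrile or a carboxylic acid in its place on the same ring. They also leave open whether it would survive on a core carrying bromine or a methyl group where the core of compound 1 carries chlorine.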